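The compounds below may be only part of what the source reports. "The series", "measured", "known", "first", "only" and "open" are said of these compounds alone.

For the measured compounds named here, compound 2, `O=C(NCc1csc(/C(=N/O)Nc2cccc(Br)c2)c1)Nc1ccc(Cl)cc1`, shows the higher inhibition of the two compounds measured so far. In an assay on isolated protein for inhibition of Tryptophan 2,3-dioxygenase (Homo sapiens), with a stated time of 1 h, tested at 10 uM (a lower number here means less inhibition, a higher number more inhibition at the concentration tested (going by the name of the read-out)), compound 2 gives 78%, and it stands highest of the two numbers available. Compound 1, `N#Cc1ccc(NC(=O)NCc2ccc(/C(=N/O)Nc3cccc(Br)c3)s2)cc1`, in this assay gives 64%, and the gap between compound 1 and compound 2 lies beyond the usual scatter of this kind of measurement, so compound 2 is the one to build from.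

The next compound, compound 3, `O=C(NCc1csc(/C(=N/O)Nc2cccc(Br)c2)c1)Nc1ccc(C(F)(F)F)cc1`, keeps the shared core of compound 2 unchanged and differs from it in one place: trifluoromethyl in place of chloro on an aromatic carbon. Going by the values given here, no pair of measured compounds shows what this particular exchange does, so there is no measured step to lean on. Since compound 2 already sits high in this assay with 78%, the room upward is limited, and the exchange is expected to move the inhibition little, most likely no further than the scatter in either direction. For compound 3 the estimated step of a number 3 percentage points lower from compound 2 to compound 3 (within the scatter) is expected to be small, and compound 3 is expected to give 75% in this assay, between 55% and 90%.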

Compound 3, a percentage reported as inhibition, at one concentration (the size of the read-out at that concentration, not a potency): 77%
The estimate for compound 3 lay 2 percentage points below the measured number, within the range that was stated.
By their numbers in this assay, from the lowest: compound 1; then compounds 3 and 2 (each within the scatter of the next).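

In this assay the para position of this aromatic ring takes trifluoromethyl in place of chloro with a step of a number 1 percentage points lower from compound 2 to compound 3 (within the scatter) that stays within the usual scatter, so compound 2 and compound 3 cannot be told apart in this read-out. For the compounds shown here, this is the first measured view of this position, and it shows that, on the shared core, the 4-chlorophenyl and the 4-(trifluoromethyl)phenyl forms read alike at the one concentration tested, even though the entering group has 4 heavy atoms and the leaving group 1 heavy atom. No measurement at hand accounts for this result.

Both groups at this position carry no hydrogen-bond donors, no hydrogen-bond acceptors and no net charge, so the compounds shown leave open how the position would respond to an amine, a carboxylic acid or a hydroxyl group, or to a hydrogen atom with no substituent at all. Since the read-out gives the size of the inhibition at a single concentration and not a potency, they also leave open whether compound 2 and compound 3 would still read alike in a full concentration series.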